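The compounds below may be only part of what the source reports. "The series", "measured", "known", "first", "only" and "open" are said of these compounds alone.

In an assay on isolated protein for inhibition of alpha-ketoglutarate-dependent dioxygenase alkB homolog 3 (Homo sapiens), read by polymerase chain reaction, with a stated time of 1 h (a lower number here means a stronger inhibitor, a higher number a weaker inhibitor), compound 1 `Cc1[nH]n(-c2ccccn2)c(=O)c1C` gives > 10000 nM, which is a limit of the assay rather than a number. Compound 2 `Cc1[nH]n(-c2nc3ccccc3[nH]2)c(=O)c1Cc1ccc(F)cc1` gives 600 nM in this assay. Compound 3 `Cc1[nH]n(-c2nc3ccccc3[nH]2)c(=O)c1Cc1ccc(Cl)cc1Cl` gives > 10000 nM in this assay, again a limit and not a measured value. Compound 3 thus stands at the weak end of the three values shown, at the limit of > 10000 nM in this assay, at which 2 of the 3 values shown sit. Among the measured compounds shown here, the only measured step that bears on the substituent on the saturated chain carbon is an at least 16-fold higher number from compound 2 to compound 3 (1.22 log units; beyond the scatter), a large loss of inhibition when the 4-fluorophenyl is replaced by 2,4-dichlorophenyl. Compound 4 `Cc1[nH]n(-c2nc3ccccc3[nH]2)c(=O)c1Cc1ccccc1Cl` differs from compound 3 by hydrogen in place of chloro on an aromatic carbon. For the measured compounds named here, no measured step removes a single chloro from this ring, so the size of the change can only be read loosely: compound 2, with a smaller halogen pattern on the ring, gave 600 nM, and compound 4 is intermediate between compound 2 and compound 3 in that respect. Compound 4 is expected to give 3000 nM in this assay, within 600 nM to 15000 nM, which means an estimated step of an at least 3.3-fold lower number from compound 3 to compound 4 (0.52 log units; beyond the scatter) toward stronger inhibition.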

Compound 4, half-maximal inhibitory concentration: > 10000 nM
Compound 4 gave a limit, no number; the forecaster's own chance of this, stated with the estimate: 40%; middle value at least 3.3-fold (0.52 log units) away from the limit.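

Compound 4 gives > 10000 nM, a limit and not a number, so taking away the chloro para to a large group does not bring back a measurable value. The step from compound 3 to compound 4 cannot be read, but an at least 16-fold higher number from compound 2 to compound 4 (1.22 log units; beyond the scatter) shows that the large loss seen with 2,4-dichlorophenyl also appears with 2-chlorophenyl, which carries a single chloro. Compound 2 therefore remains the only compound here with a measured number, and compound 4 joins the others at the ceiling: the limit of > 10000 nM in this assay, at which 3 of the 4 values shown sit.

On these data alone, what a plain phenyl group would give on the same chain carbon remains open, and with it whether the chloro itself drives the loss. Also open, as far as these compounds go, is how a methoxy group or an amine in place of that chloro would behave.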